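Compound 4: triazolyl carbonyl in place of trifluoromethyl carbonyl

The source may hold more compounds than are shown below. What is called first, only, known or untested is meant among the compounds shown, and "the series" means these compounds.

In an ADME assay on microsomes (Homo sapiens) for metabolic stability (a higher number here means that the compound lasts longer, a lower number that the compound disappears faster), compound 1 `C[C@@H]1C=NN(C(=O)C(C)(C)C)[C@@H]1c1ccccc1` gives 0.45 h and compound 3 `Cc1ccc(C2CC=NN2C(=O)C(C)(C)C)cc1F` gives 0.267 h. Compound 2 `O=C(C1CCN(C(=O)C(F)(F)F)CC1)N1N=CCC1c1ccccc1` reports only a limit in this assay, namely > 1.5 h. Compound 2 thus stands at the limit of > 1.5 h in this assay, at which 1 of the 3 values shown sits. Compound 4 `O=C(c1c[nH]nn1)N1CCC(C(=O)N2N=CCC2c2ccccc2)CC1` differs from compound 2 in one place: 1H-1,2,3-triazol-4-yl in place of trifluoromethyl on a carbonyl carbon. For the measured compounds named here, no measured pair isolates this change, so the step from compound 2 to compound 4 in this assay rests on the limit alone. The expected step is an at least 1.2-fold lower number from compound 2 to compound 4 (0.09 log units; that floor lies within the scatter), a small downward move that need not exceed the usual scatter, with the direction uncertain because compound 2 shows only > 1.5 h. Compound 4 is expected to give 1.2 h, between 0.5 h and 3 h.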

Compound 4, half-life: > 2.75 h
Compound 4: a limit, no number (the forecaster's own chance of this, stated with the estimate: 40%); at least 2.2-fold (0.36 log units) between middle value and limit.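

Compound 2 and compound 4 both report only limits in this assay, and no step can be read between them. As far as these compounds go, whether 1H-1,2,3-triazol-4-yl in place of trifluoromethyl on a carbonyl carbon changes the half-life, and in which direction, stays open.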